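The source may report more compounds than this note shows. Statements on the series, on what has been measured and on what is new or still open speak of the compounds shown alone.

Measured in a functional assay on K562 cells (Homo sapiens) for antiproliferative activity, with a stated time of 72 h; a higher number here means a weaker inhibitor, a lower number a stronger inhibitor:
Compound 1 `OC[C@H]1O[C@@H](n2cnc3c(NCc4ccccc4F)ncnc32)[C@H](O)[C@@H]1O`: 33200 nM
Compound 2 `OC[C@H]1O[C@@H](n2cnc3c(NCc4ccccc4OC(F)F)ncnc32)[C@H](O)[C@@H]1O`: > 166000 nM

For compound 2 the reading is a limit and not a number: the limit of > 166000 nM in this assay, at which 1 of the 2 values shown sits. Compound 3 `OC[C@H]1O[C@@H](n2cnc3c(NCc4ccccc4OC(F)(F)F)ncnc32)[C@H](O)[C@@H]1O` carries fluoro in place of hydrogen on a saturated chain carbon bound to two fluorine atoms and an oxygen on an aromatic ring, so difluoromethoxy becomes trifluoromethoxy (fluoro in place of hydrogen on a saturated chain carbon bound to two fluorine atoms and an oxygen on an aromatic ring). Among the measured compounds shown here, the only measured step that bears on this is an at least 5.0-fold higher number from compound 1 to compound 2 (0.69 log units; beyond the scatter), a weakening beyond the scatter, made by a related but different swap. Compound 3 is therefore expected to stay about as weak in this assay, with no step beyond the scatter. The expected change is an at least 1.1-fold lower number from compound 2 to compound 3 (0.04 log units; that floor lies within the scatter). For compound 3 the estimated value is 150000 nM, with an expected range from 60000 nM to 350000 nM.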

Compound 3, half-maximal inhibitory concentration: 81400 nM
Compound 3: middle estimate off by 1.8-fold (0.27 log units), on the high side; measured number inside the range.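

Swapping difluoromethoxy for trifluoromethoxy gives a reading that can be put as a number in this assay, with an at least 2.0-fold lower number from compound 2 to compound 3 (0.30 log units; that floor lies within the scatter). The size of that step cannot be fixed, since compound 2 has only a limit and not a number: the limit of > 166000 nM in this assay, at which 1 of the 3 values shown sits. Trifluoromethoxy still falls short of fluoro on the aromatic carbon, with a 2.5-fold higher number from compound 1 to compound 3 (0.39 log units; beyond the scatter), so neither replacement of fluoro shown here improves on compound 1.

From the compounds shown here alone, whether an amine or a carboxylic acid in this place would read better than fluoro in this assay stays open.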